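Carbamate in place of benzyl on a shared core

The compounds below may be only part of what the source reports. "The series", "measured", "known", "first", "only" and "open" are said of these compounds alone.

Compound 3 `CC(C)=CCC/C(C)=C/CC1Cc2c(OCc3ccccc3)cc(=O)n(CCCO)c2CC1(C)C` stands second highest of the three numbers in a functional assay on PANC-1 cells (Homo sapiens) for inhibition, read by MTT assay, with a stated time of 24 h, tested at 10 uM; a lower number here means less inhibition, a higher number more inhibition at the concentration tested (going by the name of the read-out): compound 3 gives 46.5%, with compound 2 `CC(C)=CCC1Cc2c(OC(=O)Nc3cccc(C(F)(F)F)c3)cc(=O)n(CCCO)c2CC1(C)C` nearest at 54.3%, within the scatter, and compound 1 `CC(C)=CCC1Cc2c(OCc3ccccc3)cc(=O)n(CCCO)c2CC1(C)C` furthest at -0.3%, beyond the scatter. Among the measured compounds shown here, the one step measured between compounds differing in a single place, a number 46.8 percentage points higher from compound 1 to compound 3 (beyond the scatter), concerns a 3-methylbut-2-en-1-yl group on the chain and does not touch the oxygen on the aromatic ring. Compound 4 `CC(C)=CCC/C(C)=C/CC1Cc2c(OC(=O)Nc3ccc(Cl)c(Cl)c3)cc(=O)n(CCCO)c2CC1(C)C` differs from compound 3 in that ((3,4-dichlorophenyl)carbamoyl in place of benzyl on an oxygen on an aromatic ring). For the measured compounds named here, no measured step covers exactly this exchange. Compound 1 and compound 2, however, differ at the same oxygen, a benzyl giving way to a carbamoyl bearing a trifluoromethyl-substituted phenyl, and their values show the carbamate reading clearly higher: compound 1 gives -0.3% and compound 2 gives 54.3%. Compound 3 already reads 46.5%, so less room lies above it, and a moderate rise of a number 13.5 percentage points higher from compound 3 to compound 4 (beyond the scatter) is expected rather than a repeat of that large gain. Compound 4 is therefore estimated at 60%, in a range from 40% to 80%.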

Compound 4, a percentage reported as inhibition, at one concentration (the size of the read-out at that concentration, not a potency): 20%
Compound 4: middle estimate off by 40 percentage points, on the high side; the whole stated range lies above it.
By their numbers in this assay, from the lowest: compound 1; then compound 4; then compounds 3 and 2 (each within the scatter of the next).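

In this assay, (3,4-dichlorophenyl)carbamoyl in place of benzyl on an oxygen on an aromatic ring gives a number 26.5 percentage points lower from compound 3 to compound 4 (beyond the scatter), so a carbamoyl at this oxygen does not raise the number in every compound. The earlier pair pointed the other way, with compound 1 at -0.3% and its carbamoyl partner compound 2 at 54.3%, but that pair carries a trifluoromethyl-substituted phenyl on the carbamoyl and lacks the 3-methylbut-2-en-1-yl group on the chain, so the exchange at this oxygen reads upward in one setting and downward in the other. Nothing given here bears on why the number fell, and the two pairs differ in both the phenyl substituents and the chain, so neither can be singled out as what sets the direction of the change.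

The compounds shown leave open how the trifluoromethyl-substituted carbamoyl behaves on the chain of compound 3, and how the (3,4-dichlorophenyl)carbamoyl behaves on the chain of compound 1. They also leave open what an amine or a carboxylic acid on the phenyl of the carbamoyl would do at this oxygen.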